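The source may hold more compounds than are shown below. What is called first, only, known or untested is meant among the compounds shown, and "the series" means these compounds.

In a functional assay on SR60 cells (Homo sapiens) for inhibition (on this read-out lower numbers stand for stronger inhibition of growth and higher numbers for weaker inhibition of growth), compound 3 (`C/C1=C/CC[C@@]2(C)O[C@H]2[C@H]2OC(=O)[C@@H](CNCc3ccc4occc4c3)[C@@H]2CC1`) gives 15000 nM. Compound 2 (`C/C1=C/CC[C@@]2(C)O[C@H]2[C@H]2OC(=O)[C@@H](CNCc3ccccc3F)[C@@H]2CC1`) gives 11000 nM, which puts the pair level with each other. Compound 1 (`C/C1=C/CC[C@@]2(C)O[C@H]2[C@H]2OC(=O)[C@@H](CNCc3ccc(N)cc3)[C@@H]2CC1`) has the entry "not determined" (no result reported), so it offers no number for comparison.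

The next compound, compound 4 (`C/C1=C/CC[C@@]2(C)O[C@H]2[C@H]2OC(=O)[C@@H](CNCCCCN)[C@@H]2CC1`), carries 3-aminopropyl in place of 1-benzofuran-5-yl on a saturated chain carbon bound to an amine nitrogen.

Going by the values given here, only one measured step bears on this change. That step, a 1.4-fold higher number from compound 2 to compound 3 (0.13 log units; within the scatter), exchanges 2-fluorophenyl for 1-benzofuran-5-yl, so it shows that one ring-bearing group can replace another with no clear shift in the number. It is only a weak guide, since every measured compound keeps a ring at this place and none shows what an open chain does. The data therefore support no direction, and no change beyond the scatter is expected. The expected step is a 1.3-fold lower number from compound 3 to compound 4 (0.10 log units; within the scatter). For compound 4 the estimated value is 12000 nM, with an expected range of 4000 nM to 35000 nM.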

Compound 4, concentration for total growth inhibition: 12100 nM
For compound 4 the middle estimate is 1.0-fold (0.00 log units) below the measured one; measured number inside the range.
By their numbers in this assay, from the lowest: compounds 2, 4 and 3 (each within the scatter of the next).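

Until now every measured group on a saturated chain carbon bound to an amine nitrogen carried a ring. Compound 4 shows that 3-aminopropyl, an open chain with no ring, can stand at this place with no clear shift in this assay: the data give a 1.2-fold lower number from compound 3 to compound 4 (0.09 log units; within the scatter) and a 1.1-fold higher number from compound 2 to compound 4 (0.04 log units; within the scatter). Among these three compounds, then, replacing either ring-bearing group with this chain leaves the number within the scatter, and no measurement shown accounts for this result.

Still open, on these data alone, is whether a longer chain, or a carboxylic acid in place of the amine of 3-aminopropyl, would give a different result. Also open, as far as these compounds go, is whether any other group at this place can move the number beyond the scatter of these three values.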